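A few compounds are considered here, and "the series" means these few. Any claim that something is new, unique, unknown or untested is made for them only; others in the source may bear on it.

Compound 1 `Fc1ccccc1N1CCN(Cn2nc(-c3ccc4c(c3)OCCO4)oc2=S)CC1` and compound 2 `COc1ccc(N2CCN(Cn3nc(-c4ccc5c(c4)OCCO5)oc3=S)CC2)cc1` share a core and differ only in the group on the amine nitrogen in a ring. In a functional assay on SW 1116 cells (Homo sapiens) for antiproliferative activity, read by MTT assay, with a stated time of 48 h (on this read-out higher numbers stand for weaker inhibition and lower numbers for stronger inhibition), compound 1 gives 37800 nM, and compound 2 gives 24200 nM. Compound 1 therefore stands as the highest of the two numbers measured, its nearest neighbour being compound 2, since a 1.6-fold lower number from compound 1 to compound 2 (0.19 log units; within the scatter). The unmeasured compound 3 `S=c1oc(-c2ccc3c(c2)OCCO3)nn1CN1CCN(c2ccccc2Cl)CC1` keeps everything of compound 1 except one atom: chloro in place of fluoro on an aromatic carbon. Among the compounds with values here, no measured step exchanges one halogen for another; the only step available, from compound 1 to compound 2, swaps a whole aryl group and stays within the scatter. Within the data shown here, with so small a change and no step pointing in either direction, compound 3 is expected to sit close to compound 1, the estimated step being a 1.2-fold lower number from compound 1 to compound 3 (0.07 log units; within the scatter). Compound 3 is thus estimated to give 32000 nM, within a range of 13000 nM to 80000 nM.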

Compound 3, half-maximal inhibitory concentration: > 50000 nM
Compound 3: only a limit was reported; the forecaster's own chance of this, stated with the estimate: 15%; middle value at least 1.5-fold (0.19 log units) from the limit.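

In this assay, going by these compounds, compound 3 gives > 50000 nM, which is a limit and not a number, and its exact value stays unknown because the reading stops there: the limit of > 50000 nM in this assay, at which 1 of the 3 values shown sits. Chloro in place of fluoro gives an at least 1.3-fold higher number from compound 1 to compound 3 (0.12 log units; that floor lies within the scatter), so at this place, on an aromatic carbon ortho to a large group, the exchange shows no sign of a lower number, yet its floor alone does not separate the two compounds. Within the data shown here, the 2-chlorophenyl group in place of 4-methoxyphenyl gives an at least 2.0-fold higher number from compound 2 to compound 3 (0.31 log units; beyond the scatter), the first step in this set to pass the scatter.

On these data alone, how far the true value of compound 3 lies past its limit remains open. So does the question of whether bromo, methyl or an amine on the same aromatic carbon would change the number.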